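Swapping an aromatic ring for a saturated one

A few compounds are considered here, and "the series" means these few. Any claim that something is new, unique, unknown or untested is made for them only; others in the source may bear on it.

Compound 1 `Cc1ccc(C(=O)Nc2nnc(-c3ccc(O)c(O)c3)s2)cc1` and compound 2 `O=C(Nc1nnc(-c2ccc(O)c(O)c2)s1)C1CCCCC1` share one core, built around an amide, and differ only in the group attached to the carbonyl carbon. In a functional assay on HL-60 cells (Homo sapiens) for cytotoxicity, read by MTT assay, with a stated time of 72 h (a lower number here means a stronger inhibitor, a higher number a weaker inhibitor), compound 1 gives 10500 nM and compound 2 gives 8800 nM. The change that separates them is cyclohexyl in place of 4-methylphenyl on a carbonyl carbon, and it made a 1.2-fold lower number from compound 1 to compound 2 (0.08 log units; within the scatter).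

Compound 3 `Cc1ccc(C(=O)Nc2nnc(-c3cccc(O)c3O)s2)cc1` contains the same atoms as compound 1, joined differently; the difference between the two cores is not broken down here. In this assay compound 3 gives 10600 nM, a number that sits close to those of compound 1 and compound 2.

Compound 4 `O=C(Nc1nnc(-c2cccc(O)c2O)s1)C1CCCCC1` has not yet been measured. It stands to compound 3 exactly as compound 2 stands to compound 1: the difference is cyclohexyl in place of 4-methylphenyl on a carbonyl carbon, and the surroundings of the change are the same in both pairs, so this is the same change made on a second core.

The step from compound 3 to compound 4 is expected to be a 1.2-fold lower number from compound 3 to compound 4 (0.08 log units; within the scatter), resting on the earlier step, which was a 1.2-fold lower number from compound 1 to compound 2 (0.08 log units; within the scatter) and lay within the scatter of the method. Compound 4 is therefore estimated at 8900 nM, most likely falling between 4500 nM and 18000 nM.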

Compound 4, half-maximal inhibitory concentration: 7900 nM
Estimate against measurement, compound 4: 1.1-fold (0.05 log units) above; the range from low to high includes it.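

In this assay, putting cyclohexyl in place of 4-methylphenyl on the carbonyl carbon gives a 1.3-fold lower number from compound 3 to compound 4 (0.13 log units; within the scatter), and this step agrees with the earlier one on the other core: the same change on two cores in this assay, a 1.2-fold lower number (0.08 log units; within the scatter) from compound 1 to compound 2 and a 1.3-fold lower number (0.13 log units; within the scatter) from compound 3 to compound 4, 1.1-fold (0.05 log units) apart, within the scatter of two such steps. Each step lies within the scatter of the method, so what carries across the two cores is the lack of a measurable effect, not a real gain in activity: at this place, as far as this read-out can tell, the saturated ring and the aromatic ring are interchangeable. This does not show that the change would behave the same way on any further core, and a change this small is a weak test of transfer, as a true effect small enough to hide in the scatter could still differ between the two cores.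

The compounds shown leave open whether a different kind of group on the carbonyl carbon, such as a longer carbon chain, an amine or a carboxylic acid, would move the number beyond the scatter. They also leave open whether the agreement between the two cores would hold in any other assay.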